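A few compounds are considered here, and "the series" means these few. Any claim that something is new, unique, unknown or untested is made for them only; others in the source may bear on it.

Three compounds share the same core and were all tested in a functional assay on NCI/ADR-RES cells (Homo sapiens) for cytotoxicity, read by sulforhodamine B assay, with a stated time of 48 h, tested at 0.001 uM; a lower number here means a stronger effect, a higher number a weaker effect of the compound at the concentration tested. Compound 1 `COc1cc(C)cc(-c2c(-c3ccnc(-c4ccc(C(C)=O)cc4)c3)cnn2CC#N)c1` gives 95%. Compound 2 `COc1cc(C)cc(-c2nn(CC#N)cc2-c2ccc(-c3cccc(C(C)=O)c3)nc2)c1` gives 99%. Compound 3 `Cc1cc(O)cc(-c2nn(CC#N)cc2-c2ccnc(-c3ccc(Oc4ccccc4)cc3)c2)c1` gives 105%, and its number is the highest of the three, but the gap to compound 2 and the gap to compound 1 both lie within the usual scatter of the measurement, so the three readings cannot be told apart; each of them says that very little of the cell growth was lost at this concentration.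

Compound 4 `Cc1cc(O)cc(-c2nn(CC#N)cc2-c2ccnc(-c3ccc(N(C)C)cc3)c2)c1` has not yet been measured. It differs from compound 3 in one place: dimethylamino in place of phenoxy on an aromatic carbon. For the measured compounds named here, no measured pair shows what this kind of change does, so the expectation can rest only on the three readings already in hand, which all sit close together.

The step expected from compound 3 to compound 4 in this assay is a number 5 percentage points lower from compound 3 to compound 4 (within the scatter), which is no step beyond the scatter. Compound 4 is therefore estimated to give 100%, with a range from 85% to 112%.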

Compound 4, a percentage reported as activity, at one concentration (the size of the read-out at that concentration, not a potency): 97%
The estimate for compound 4 lay 3 percentage points above the measured number, and the stated range covers the measured number.
By their numbers in this assay, from the lowest: compounds 1, 4, 2 and 3 (each within the scatter of the next).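

In this assay, the change gives a number 8 percentage points lower from compound 3 to compound 4 (within the scatter). This is the first pair among these compounds that differs in only one place, and it shows that on this aromatic carbon, para to a large group, a phenoxy group with its ring and 7 heavy atoms can give way to a dimethylamino group with no ring and 3 heavy atoms without a reading that can be told apart from that of compound 3. No measurement here accounts for this result.

Going by these compounds, whether a carboxylic acid or a longer chain ending in an amine on the same carbon would move the reading beyond the scatter remains open. Because the read-out comes from one concentration, it also leaves open whether compound 3 and compound 4 would differ at higher concentrations.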